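The source may report more compounds than this note shows. Statements on the series, on what has been measured and on what is new or still open speak of the compounds shown alone.

Values in a functional assay for inhibition, with Homo sapiens as the target; on this read-out lower numbers stand for stronger inhibition and higher numbers for weaker inhibition:
- compound 1 `CC(C)(C)Sc1c(CC(C)(C)C(=O)O)n(Cc2ccc(Cl)cc2)c2ccc(OCc3cc4ccccc4cn3)cc12`: 3 nM
- compound 2 `CC(C)(C)Sc1c(CC(C)(C)C(=O)O)n(Cc2ccc(Cl)cc2)c2ccc(OCc3ccc4cccnc4n3)cc12`: 6 nM
- compound 3 `CC(C)(C)Sc1c(CC(C)(C)C(=O)O)n(Cc2ccc(Cl)cc2)c2ccc(OCc3nc4ccccc4o3)cc12`: < 7 nM (a limit)

Compound 3 has no number in this assay, only the limit < 7 nM. The record for the series reads: the limit of < 7 nM in this assay, at which 1 of the 3 values shown sits.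

The next step leads to compound 4 `CC(C)(C)Sc1c(CC(C)(C)C(=O)O)n(Cc2ccc(Cl)cc2)c2ccc(OCc3cccnc3)cc12`, with pyridin-3-yl in place of 1,3-benzoxazol-2-yl on a saturated chain carbon bound to an oxygen on an aromatic ring.

Within the data shown here, only one measured step at this place has a readable size: a 2.0-fold higher number from compound 1 to compound 2 (0.30 log units; within the scatter). The two steps into compound 3, a step that the limit leaves unreadable from compound 1 to compound 3 and a step that the limit leaves unreadable from compound 2 to compound 3, give no size. None of these steps leaves a single six-membered aromatic ring at this place, so the change to compound 4 goes beyond what has been measured. The step of a 2.0-fold higher number from compound 1 to compound 2 (0.30 log units; within the scatter) shows that exchanging one larger group for another left the read-out within the scatter, but it says little about removing a ring. A modest move toward a higher number, meaning weaker inhibition, is therefore expected, with wide uncertainty. The expected step is an at least 1.7-fold higher number from compound 3 to compound 4 (0.23 log units; that floor lies within the scatter). For compound 4 the estimated value is 12 nM, with an expected range of 3 nM to 50 nM.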

Compound 4, half-maximal inhibitory concentration: 8 nM
Beside the measured number, compound 4's estimate is 1.5-fold (0.18 log units) above it; low and high end bracket the measured number.
By their numbers in this assay, from the lowest: compounds 1, 2 and 4 (each within the scatter of the next, the first and the last beyond it).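

In this assay, a single six-membered aromatic ring on the saturated chain carbon bound to an oxygen on an aromatic ring can stand in for a two-ring group without a readable loss in one pair: a 1.3-fold higher number from compound 2 to compound 4 (0.12 log units; within the scatter). Among these compounds, the same exchange against isoquinolin-3-yl gives the first step at this place that lies beyond the scatter, a 2.7-fold higher number from compound 1 to compound 4 (0.43 log units; beyond the scatter), so removing a ring has a modest cost in that pair, and compound 2 goes against any general cost. The 1,3-benzoxazol-2-yl group is represented only by a limit, and its exchange gives a floor alone, an at least 1.1-fold higher number from compound 3 to compound 4 (0.05 log units; that floor lies within the scatter), with no true size to read: the limit of < 7 nM in this assay, at which 1 of the 4 values shown sits.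

On these data alone, whether the ring nitrogen of pyridin-3-yl matters stays open, as the single-ring series here holds neither phenyl nor pyridin-2-yl or pyridin-4-yl for comparison. Also open, as far as these compounds go, is whether an aromatic ring is needed at this place at all, a question that a morpholine, a simple amine or a longer alkyl chain on the same saturated chain carbon would address.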